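The compounds below may be only part of what the source reports. "The series", "measured", "known", "first", "only" and "open" are said of these compounds alone.

Of the compounds shown here, two have been measured so far. Compound 1 `CCc1nc(C(=O)c2ccc(C)s2)c2sccc2n1` and compound 2 `O=C(c1nccs1)c1nc(NCc2cccnc2)nc2ccsc12` share the same core, and both were tested in a functional assay on CHO-K1 cells for antagonist activity at adenosine receptor A2b (Homo sapiens), read by FLIPR and calcium flux; on this read-out lower numbers stand for stronger inhibition and higher numbers for weaker inhibition. In this assay compound 1 gives 3670 nM. Compound 2 gives 176 nM. Compound 2 therefore stands at the lower, stronger end of the two numbers, and its gap to compound 1 is wide enough to lie beyond the usual scatter of repeated measurements.

The next compound, compound 3 `CC(C)NC(=O)c1nc(NCc2cccnc2)nc2ccsc12`, differs from compound 2 in one place: isopropylamino in place of 1,3-thiazol-2-yl on a carbonyl carbon. The carbonyl that carried a small aromatic ring now carries an amine with a short branched chain, so the ketone becomes an amide. Within the data shown here, no measured pair shows what such a swap does, so the direction and size of the step can only be estimated.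

Because compound 2 gives 176 nM, and the change removes an aromatic ring from the carbonyl, a moderate loss of inhibition is expected, a step of about a 3.4-fold higher number from compound 2 to compound 3 (0.53 log units; beyond the scatter). Compound 3 is therefore estimated at 600 nM, with a likely range from 150 nM to 3000 nM.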

Compound 3, half-maximal inhibitory concentration: 309 nM
The estimate for compound 3 lay 1.9-fold (0.29 log units) above the measured number; measured number inside the range.
By their numbers in this assay, from the lowest: compounds 2 and 3 (each within the scatter of the next); then compound 1.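

In this assay the swap of 1,3-thiazol-2-yl for isopropylamino on a carbonyl carbon gives a 1.8-fold higher number from compound 2 to compound 3 (0.24 log units; within the scatter) and so leaves the two numbers indistinguishable. Among these compounds, this is the first look at this position, and it shows that a ketone carrying a five-membered aromatic ring and an amide carrying a short branched chain with no ring read alike here, so for this pair the ring on the carbonyl is not needed to hold the number at this level, and the hydrogen-bond donor that enters does not move it beyond the scatter. Nothing measured here explains why the two numbers lie so close. The compounds shown leave open whether a dimethylamino group, which has no amide hydrogen, or a longer chain such as n-butylamino would read the same on this carbonyl carbon. They also leave open whether a phenyl ring or a carboxylic acid in this place would keep the number at this level, and a single pair cannot show how far this position's latitude extends.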